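The source may hold more compounds than are shown below. What is called first, only, known or untested is meant among the compounds shown, and "the series" means these compounds.

Working notes on the tri-sulfated methyl glycoside series.

Compound 1, `CCN(CC(=O)NC[C@H]1O[C@H](OC)[C@@H](OS(=O)(=O)O)[C@@H](OS(=O)(=O)O)[C@@H]1OS(=O)(=O)O)C(=O)CCCCC(=O)O`, gives 160000 nM in an assay on isolated protein for binding affinity to fibroblast growth factor 1 (Homo sapiens), read by surface plasmon resonance; on this read-out higher numbers stand for weaker binding and lower numbers for tighter binding. Among the compounds with values here, it holds the lowest of the three numbers so far, though both neighbours sit within the scatter: compound 2, `CO[C@H]1O[C@H](CNC(=O)CN(C(C)=O)c2ccccc2)[C@@H](OS(=O)(=O)O)[C@H](OS(=O)(=O)O)[C@@H]1OS(=O)(=O)O`, gives 196000 nM, and compound 3, `CO[C@H]1O[C@H](CNC(=O)CN(C(C)=O)C2CCCCC2)[C@@H](OS(=O)(=O)O)[C@H](OS(=O)(=O)O)[C@@H]1OS(=O)(=O)O`, gives 310000 nM. The steps of a 1.2-fold higher number from compound 1 to compound 2 (0.09 log units; within the scatter) and a 1.9-fold higher number from compound 1 to compound 3 (0.29 log units; within the scatter) replace the whole acyl side of the amide-type nitrogen without moving the number beyond the scatter, and a 1.6-fold higher number from compound 2 to compound 3 (0.20 log units; within the scatter) does the same for cyclohexyl against phenyl.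

Compound 4, `CCN(CC(=O)NC[C@H]1O[C@H](OC)[C@@H](OS(=O)(=O)O)[C@@H](OS(=O)(=O)O)[C@@H]1OS(=O)(=O)O)C(=O)CCCc1ccccc1`, keeps the ethyl and the chain of compound 1 and differs only at its far end: phenyl in place of carboxymethyl on a saturated chain carbon, three bonds along the chain from a carbonyl carbon. Within the data shown here, no measured step touches this exact position, but every change so far on this side of the molecule has stayed within the scatter, whether the group was aliphatic, aromatic or carboxylate-bearing. The expectation is therefore no step beyond the scatter, with the estimated step of a 1.3-fold higher number from compound 1 to compound 4 (0.10 log units; within the scatter). Compound 4 is expected to give about 200000 nM, with a range from 80000 nM to 500000 nM.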

Compound 4, dissociation constant: 500000 nM
Estimate against measurement, compound 4: 2.5-fold (0.40 log units) below, within the range that was stated.
By their numbers in this assay, from the lowest: compounds 1, 2, 3 and 4 (each within the scatter of the next, the first and the last beyond it).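

In this assay, within the data shown here, the step of a 3.1-fold higher number from compound 1 to compound 4 (0.49 log units; beyond the scatter) is the first to pass the scatter, and it comes from a single change: phenyl in place of carboxymethyl on a saturated chain carbon, three bonds along the chain from a carbonyl carbon. The earlier steps shown here, all within the scatter, replaced larger parts of this side of the molecule, so this position is not silent, although the step is only modest. No evidence on hand bears on the reason for this step.

Because carboxymethyl leaves as phenyl enters, the compounds shown do not separate the loss of the one from the gain of the other. An amine or a primary amide in the same place would help to tell these apart.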